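The source may report more compounds than this note shows. Statements on the series, on what has been measured and on what is new or still open speak of the compounds shown alone.

Compound 1 `CN(Cc1ccc(OCCCN)cc1)c1nc2ccc(Oc3ccc(C#N)cc3)cc2s1` — 65000 nM
Compound 2 `CN(Cc1ccc(OCCCNC(=N)N)cc1)c1nc2ccc(Oc3ccc(C#N)cc3)cc2s1` — 143000 nM
Compound 3 `CN(C)CCCOc1ccc(CNc2nc3ccc(Oc4ccc(C#N)cc4)cc3s2)cc1` — 105000 nM

All three compounds were tested in an assay on SH-SY5Y cells for inhibition of Voltage-dependent N-type calcium channel subunit alpha-1B (Homo sapiens), read by FLIPR and calcium flux, with stated times of 600 s and 300 s, in the presence of a further agent that is not named here; a higher number here means a weaker inhibitor, a lower number a stronger inhibitor. Compound 3 gives 105000 nM, the second highest of the three numbers. Its nearest neighbour is compound 2, whose value lies within the scatter of that of compound 3; compound 1 lies on the other side, also within the scatter. Among the measured compounds shown here, the one step that can be read directly is the change at the amine nitrogen of the side chain, where the numbers move from compound 1 to compound 2 by a 2.2-fold higher number from compound 1 to compound 2 (0.34 log units; beyond the scatter), a modest shift.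

Compound 4 `CN(C)CCCOc1ccc(CN(C)c2nc3ccc(Oc4ccc(C#N)cc4)cc3s2)cc1` differs from compound 3 by methyl in place of hydrogen on a nitrogen on an aromatic ring. For the measured compounds named here, none of the measured steps concerns this position: compound 1 and compound 2 both already carry the methyl there, but they differ from compound 3 at the side chain as well, so no single step isolates the methyl. What the numbers do show is that compound 1 and compound 3, which differ in two places, sit within the scatter of each other.

With nothing pointing either way, the expected step in this assay from compound 3 to compound 4 is a 1.1-fold lower number from compound 3 to compound 4 (0.02 log units; within the scatter), none beyond the scatter. Compound 4 is therefore estimated at 100000 nM, with a range from 40000 nM to 250000 nM.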

Compound 4, half-maximal inhibitory concentration: 69000 nM
Compound 4: middle estimate off by 1.4-fold (0.16 log units), on the high side; low and high end bracket the measured number.
By their numbers in this assay, from the lowest: compounds 1, 4, 3 and 2 (each within the scatter of the next, the first and the last beyond it).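

Among the compounds shown here, with the methyl step now isolated, this assay shows that methyl in place of hydrogen on a nitrogen on an aromatic ring gives a 1.5-fold lower number from compound 3 to compound 4 (0.18 log units; within the scatter) and does not separate the two compounds, a point the earlier compounds could not settle. The series also now shows that, on a saturated chain carbon, three bonds along the chain from an oxygen on an aromatic ring, dimethylamino in place of amino gives a 1.1-fold higher number from compound 1 to compound 4 (0.03 log units; within the scatter) and does not separate those compounds either, whereas dimethylamino in place of the larger group of compound 2 gives a 2.1-fold lower number from compound 2 to compound 4 (0.32 log units; beyond the scatter) and is a modest step beyond the scatter. No measured evidence is available to explain any of these steps.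

The compounds shown leave open whether an ethyl or a benzyl group on that nitrogen would give a step beyond the scatter, and whether the methyl step would read the same with amino on the side chain. They also leave open how a carboxylic acid, a piperidine or a longer chain at the side-chain position would compare with dimethylamino.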